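This account rests on a few compounds, and the source may have more. Where it says the series, first, only, none or still open, it means among the compounds named here.

The measured compounds:
compound 1, `NC(=O)CN1CCC2(N3CCCCC3)CC(c3ccc(Cl)cc3)C1C(c1ccc(Cl)cc1)C2`, 23800 nM in an ADME assay on L6 cells (Rattus norvegicus) for cytotoxicity, read by resazurin assay, with a stated time of 72 h; a higher number here means a weaker inhibitor, a lower number a stronger inhibitor
compound 2, `CCOC(=O)CN1CCC2(N3CCCCC3)CC(c3ccc(Cl)cc3)C1C(c1ccc(Cl)cc1)C2`, 13100 nM
compound 3, `CN(C)C12CCNC(C(c3cccc4ccccc34)C1)C(c1cccc3ccccc13)C2`, 6470 nM

Compound 1 gives the highest of these three numbers. Its nearest neighbour is compound 2, reached by a 1.8-fold lower number from compound 1 to compound 2 (0.26 log units; within the scatter). Compound 3 differs from compound 1 in several places at once, and its number is clearly lower.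

Compound 4, `NCCN1CCC2(N3CCCCC3)CC(c3ccc(Cl)cc3)C1C(c1ccc(Cl)cc1)C2`, differs from compound 1 in one place: aminomethyl in place of carbamoyl on a saturated chain carbon bound to an amine nitrogen in a ring. Among the compounds with values here, the only measured step at this chain end is the one from compound 1 to compound 2, which kept the carbonyl and stayed within the scatter; no measured step removes the carbonyl itself. A step of about a 1.6-fold lower number from compound 1 to compound 4 (0.20 log units; within the scatter) is therefore expected, leaning toward a lower number but uncertain. For compound 4 the expected value in this assay is 15000 nM, in a range from 6000 nM to 40000 nM.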

Compound 4, half-maximal inhibitory concentration: 3370 nM
For compound 4 the middle estimate is 4.5-fold (0.65 log units) above the measured one; measured number outside the range, below it.
By their numbers in this assay, from the lowest: compounds 4 and 3 (each within the scatter of the next); then compounds 2 and 1 (each within the scatter of the next).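

Within the data shown here, at this chain end in this assay, the carbonyl matters more than the earlier compounds suggested. Aminomethyl in place of carbamoyl gives a step beyond the scatter (a 7.1-fold lower number from compound 1 to compound 4 (0.85 log units; beyond the scatter)), as does aminomethyl in place of ethoxycarbonyl (a 3.9-fold lower number from compound 2 to compound 4 (0.59 log units; beyond the scatter)), whereas exchanging one carbonyl group for the other stayed within it (a 1.8-fold lower number from compound 1 to compound 2 (0.26 log units; within the scatter)). Nothing shown here accounts for this shift.

Still open, as far as these compounds go, is whether the terminal amine nitrogen contributes, or whether simply removing the carbonyl is enough. A carboxylic acid, a dimethylamine or a longer chain ending in an amine at this place could help separate those readings.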